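A few compounds are considered here, and "the series" means these few. Any claim that something is new, unique, unknown or untested is made for them only; others in the source may bear on it.

Compound 2 `CN1CCN(CCNCc2cn(-c3ccc(F)cc3F)nc2-c2ccc(N(C)C)cc2)CC1` is one of two members of this series measured in an ADME assay on Huh-7 cells (Homo sapiens) for cytotoxicity; on this read-out higher numbers stand for lower toxicity in this test and lower numbers for higher toxicity in this test. In this assay compound 2 gives > 20000 nM, which is a limit of the assay. Its companion, compound 1 `Cc1cccc(-c2nn(-c3ccc(F)cc3F)cc2CNCCN2CCN(C)CC2)c1`, likewise gives > 20000 nM in this assay, also a limit. The step that the two limits leave unreadable from compound 1 to compound 2 therefore cannot be read, since both values sit at the limit of > 20000 nM in this assay, at which 2 of the 2 values shown sit. Compound 3 `CN1CCN(CCNCc2cn(-c3ccc(F)cc3F)nc2-c2ccc(Cl)cc2)CC1` differs from compound 2 by chloro in place of dimethylamino on an aromatic carbon. For the measured compounds named here, no measured step reads on this change, so no shift beyond the scatter is expected, and compound 3 is estimated at a step that the limit leaves unreadable from compound 2 to compound 3. Compound 3 is accordingly expected to give 25000 nM in this assay, within 8000 nM to 80000 nM, most likely again as a limit.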

Compound 3, half-maximal cytotoxic concentration: 19000 nM
For compound 3 the middle estimate is 1.3-fold (0.12 log units) above the measured one; low and high end bracket the measured number.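

Among the three compounds, only compound 3, with chloro on this aromatic carbon, gives a number in this assay rather than a limit. The change from dimethylamino gives an at least 1.0-fold lower number from compound 2 to compound 3 (0.02 log units; that floor lies within the scatter), and 4-chlorophenyl in place of 3-methylphenyl gives an at least 1.0-fold lower number from compound 1 to compound 3 (0.02 log units; that floor lies within the scatter), so neither change is shown to go beyond the scatter. Both steps start from a limit and remain floors: the limit of > 20000 nM in this assay, at which 2 of the 3 values shown sit.

On these data alone, the true size of these steps stays open. So does whether a nitrile, a carboxylic acid or a longer chain on this aromatic carbon would give a step beyond the scatter.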